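A few compounds are considered here, and "the series" means these few. Any claim that something is new, unique, unknown or untested is made for them only; others in the source may bear on it.

Compound 1 `CCOC(=O)CN(Cc1ccccc1)c1nc(NCc2ccccc2)ncc1[N+](=O)[O-]`: > 100000 nM
Compound 2 `CCOC(=O)CN(Cc1ccccc1)c1nc(NCc2cccc(OC)c2)ncc1[N+](=O)[O-]`: 57400 nM
Compound 3 `CCOC(=O)CNc1nc(NCc2ccccc2)ncc1[N+](=O)[O-]`: 52400 nM

In a functional assay on MCF7 cells (Homo sapiens) for antiproliferative activity, read by MTT assay, with a stated time of 48 h (on this read-out higher numbers stand for weaker inhibition and lower numbers for stronger inhibition), compound 1 stands only at the limit of > 100000 nM in this assay, at which 1 of the 3 values shown sits, which is a limit of the assay and not a number. Two measured steps start from it: an at least 1.7-fold lower number from compound 1 to compound 2 (0.24 log units; that floor lies within the scatter) with a methoxy in place of hydrogen on an aromatic carbon, and an at least 1.9-fold lower number from compound 1 to compound 3 (0.28 log units; that floor lies within the scatter) with hydrogen in place of benzyl on a nitrogen on an aromatic ring. Compound 4 `CCOC(=O)CN(Cc1ccccc1)c1nc(Nc2ccc(Cl)cc2)ncc1[N+](=O)[O-]` differs from compound 1 by 4-chlorophenyl in place of benzyl on a nitrogen on an aromatic ring. Neither measured step touches that place, and both start from a limit, so they give no firm size for this step. Compound 4 is therefore expected to stay weak, with an at least 1.6-fold lower number from compound 1 to compound 4 (0.22 log units; that floor lies within the scatter) and an estimate of 60000 nM, between 15000 nM and 200000 nM.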

Compound 4, half-maximal inhibitory concentration: > 100000 nM
Compound 4: a limit, no number; the forecaster's own chance of this, stated with the estimate: 40%; at least 1.6-fold (0.22 log units) between middle value and limit.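

In this assay compound 4 gives > 100000 nM, a limit of the assay and not a number, so a 4-chlorophenyl on this nitrogen leaves the compound at the limit, as benzyl does in compound 1. The step between those two compounds cannot be read, as both ends are limits. For the compounds shown here, the one readable step is an at least 1.7-fold higher number from compound 2 to compound 4 (0.24 log units; that floor lies within the scatter), with 4-chlorophenyl in place of 3-methoxybenzyl on the nitrogen.

Going by these compounds, how an amine or a carboxylic acid at this place would read in this assay stays open. Also open, on these data alone, is what 4-chlorophenyl would do in compound 3, which has hydrogen in place of the other benzyl.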